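This account rests on a few compounds, and the source may have more. Where it says the series, first, only, none or still open, it means among the compounds named here.

Measured so far:
compound 1 `CC(O)(COc1ccc(S(F)(F)(F)(F)F)cc1)C(=O)Nc1ccc(S(F)(F)(F)(F)F)cc1` gives 9300 nM
compound 2 `CC(O)(CS(=O)(=O)c1ccc(S(F)(F)(F)(F)F)cc1)C(=O)Nc1ccc([N+](=O)[O-])cc1C(F)(F)F` gives 28600 nM
compound 3 `CC(O)(CS(=O)(=O)c1ccc(S(F)(F)(F)(F)F)cc1)C(=O)Nc1ccc(S(F)(F)(F)(F)F)cc1` gives 15700 nM

All three values come from a functional assay on VCaP cells (Homo sapiens) for antiproliferative activity, read by propidium iodide staining, with a stated time of 96 h (a lower number here means a stronger inhibitor, a higher number a weaker inhibitor), and are the only data available for the series. Compound 3, at 15700 nM, lies within the scatter of compound 1 and also within the scatter of compound 2, so the numbers do not separate it from either.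

Compound 4 `CC(O)(CS(=O)(=O)c1ccc(C(F)(F)F)cc1)C(=O)Nc1ccc(S(F)(F)(F)(F)F)cc1` has not yet been measured. It differs from compound 3 in one place, on an aromatic carbon of a six-membered aromatic ring of carbon only, para to a large group: a group of 4 heavy atoms (1 carbon, 3 fluorine; no ring) in place of a group of 6 heavy atoms (5 fluorine, 1 sulfur; no ring), on an aromatic carbon. Trifluoromethyl enters there, and the rest of the structure stays the same.

For the measured compounds named here, no measured pair shows this exchange, so the data give no direct reading of its size. The expectation therefore stays close to compound 3 at 15700 nM, and no step beyond the scatter is expected in this assay. The estimate gives a 1.0-fold lower number from compound 3 to compound 4 (0.02 log units; within the scatter) as the expected step. For compound 4 the estimated value is 15000 nM, with an expected range from 7000 nM to 35000 nM.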

Compound 4, half-maximal inhibitory concentration: 27700 nM
Estimate against measurement, compound 4: 1.8-fold (0.27 log units) below; the measured number falls inside the stated range.
By their numbers in this assay, from the lowest: compounds 1, 3, 4 and 2 (each within the scatter of the next, the first and the last beyond it).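

In this assay, for the compounds shown here, the exchange of the group of 6 heavy atoms (5 fluorine, 1 sulfur) for trifluoromethyl, on an aromatic carbon of the six-membered aromatic ring of carbon only and para to a large group, gives a 1.8-fold higher number from compound 3 to compound 4 (0.25 log units; within the scatter) and so provides the first reading of a one-place change. The two compounds are not separated by the numbers, so on this single pair the position tolerates either group without a step beyond the scatter, something compounds 1 and 2 could not show because neither forms a one-place pair with another measured compound. No available measurement bears on why the two groups read alike here.

Going by these compounds alone, still open is whether a group of a different kind at this position, such as a nitrile, an amine or a carboxylic acid, would produce a step beyond the scatter, since the only two groups compared here both carry several fluorine atoms. Also open, on these data alone, is whether trifluoromethyl would read the same way in place of the matching group in compound 2, which would test whether this single result holds beyond the setting of compound 3.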